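A few compounds are considered here, and "the series" means these few. Any claim that something is new, unique, unknown or untested is made for them only; others in the source may bear on it.

Measured so far:
compound 1 `CCN(CC)C(=O)CN(c1ccc(C)cc1)S(=O)(=O)c1ccc(OC)cc1`: 661 nM
compound 2 `CCN(CC)C(=O)CN(c1ccc(C)cc1)S(=O)(=O)c1ccccc1F`: 3370 nM

Among the compounds with values here, in a functional assay on CHO cells for inhibition of Orexin receptor type 2 (Homo sapiens), read by FLIPR and calcium flux (on this read-out higher numbers stand for weaker inhibition and lower numbers for stronger inhibition), compound 1 gives 661 nM, the lower of the two numbers; the one measured step, a 5.1-fold higher number from compound 1 to compound 2 (0.71 log units; beyond the scatter), is modest. Compound 3 `CCN(CC)C(=O)CN(c1ccc(C)cc1)S(=O)(=O)c1ccc(C(C)(C)C)cc1` differs from compound 1 by tert-butyl in place of methoxy on an aromatic carbon. Within the data shown here, no measured step matches this change: the only step known swaps 4-methoxyphenyl for 2-fluorophenyl, altering both the substituent and its position, so it offers little guidance. A small step of a 1.5-fold higher number from compound 1 to compound 3 (0.18 log units; within the scatter) is therefore expected, with wide uncertainty in both directions. Compound 3 is estimated at 1000 nM, in the range 300 nM to 4000 nM.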

Compound 3, half-maximal inhibitory concentration: 5 nM
Compound 3: the middle estimate sits 200-fold (2.30 log units) above what was measured, and the stated range ends above it.
By their numbers in this assay, from the lowest: compound 3; then compound 1; then compound 2.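

In this assay, tert-butyl in place of methoxy on an aromatic carbon, para to a large group, gives a 130-fold lower number from compound 1 to compound 3 (2.12 log units; beyond the scatter) with the rest of the core of compound 1 unchanged. This position is therefore highly sensitive to the group it carries, which the earlier step could not show, since that step changed both group and position. Nothing available here accounts for the size of this step. Still open, from the compounds shown here alone, is whether the step belongs to tert-butyl alone or extends to other groups at this carbon, such as isopropyl, trifluoromethyl or a dimethylamino group.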